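Rhodanine sulfonamide series: cytotoxicity on HFF cells, trifluorophenyl analogue

The source may report more compounds than this note shows. Statements on the series, on what has been measured and on what is new or still open speak of the compounds shown alone.

Measured compounds:
compound 1 `Cc1ccc(/C=C2\SC(=S)N(NS(=O)(=O)c3ccccc3)C2=O)cc1` — > 100000 nM
compound 2 `O=C1/C(=C/c2ccccc2F)SC(=S)N1NS(=O)(=O)c1ccccc1` — > 100000 nM
compound 3 `O=C1/C(=C/c2ccc(Cl)c(Cl)c2)SC(=S)N1NS(=O)(=O)c1ccccc1` — > 100000 nM

In a functional assay on HFF cells (Homo sapiens) for cytotoxicity (on this read-out higher numbers stand for weaker inhibition and lower numbers for stronger inhibition), compound 1 gives > 100000 nM, which is a limit of the assay and not a number. In this assay compound 2 likewise gives only a limit, > 100000 nM. In this assay compound 3 also gives only a limit, > 100000 nM. Among the measured compounds shown here, because of the limit of > 100000 nM in this assay, at which 3 of the 3 values shown sit, no measured step can be read: a step that the two limits leave unreadable from compound 1 to compound 2, a step that the two limits leave unreadable from compound 1 to compound 3 and a step that the two limits leave unreadable from compound 2 to compound 3 all stay hidden behind the same limit. Compound 1 therefore stands nowhere on a scale, only at the limit.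

Compound 4 `O=C1/C(=C/c2cc(F)c(F)cc2F)SC(=S)N1NS(=O)(=O)c1ccccc1` is the next analogue. It differs from compound 1 in one place: 2,4,5-trifluorophenyl in place of 4-methylphenyl on a double-bonded chain carbon bound to a double-bonded ring carbon. The measured steps bearing on it are the three aryl exchanges already made, each of which left the limit unchanged in this assay, so no direction or size of step can be drawn from them. The expectation for the step from compound 1 to compound 4 is accordingly a step that the limit leaves unreadable from compound 1 to compound 4, meaning no change that the assay could resolve. Compound 4 is therefore expected in this assay to give about 200000 nM, with the likely range 60000 nM to 800000 nM, and most probably again only a limit.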

Compound 4, half-maximal inhibitory concentration: > 100000 nM
Compound 4 gave a limit, no number; the forecaster's own chance of this, stated with the estimate: 85%; the middle value lies beyond the limit too.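

Among the compounds shown here, no step to compound 4 from compound 1, compound 2 or compound 3 can be read in this assay, where all four compounds give only a limit and no number: the limit of > 100000 nM in this assay, at which 4 of the 4 values shown sit. The compounds shown leave open whether any of these aryl exchanges on the shared core changes cytotoxicity in this assay at all, and by how much.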